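An Amino Group Added to Compound 2

A few compounds are considered here, and "the series" means these few. Any claim that something is new, unique, unknown or untested is made for them only; others in the source may bear on it.

In a functional assay (Mus musculus) for cytotoxicity (a lower number here means that less compound is tolerated, a higher number that more compound is tolerated), compound 1 (`O=C(NNC(=O)c1ccc([N+](=O)[O-])o1)c1ccc([N+](=O)[O-])o1`) gives 32000 nM, compound 2 (`O=C(Cc1ccccc1)NNC(=O)c1ccc([N+](=O)[O-])o1`) gives 32000 nM and compound 3 (`O=C(NNC(=O)c1cccc2ccccc12)c1ccc([N+](=O)[O-])o1`) gives 32000 nM. Compound 2 thus stands level with the other two, and the data show no order among them. Compound 4 (`N[C@@H](C(=O)NNC(=O)c1ccc([N+](=O)[O-])o1)c1ccccc1`) differs from compound 2 by one change: amino in place of hydrogen on a saturated chain carbon bound to an aromatic carbon and a carbonyl carbon. Going by the values given here, no measured pair shows a change at a single place, so the expectation rests only on these level values. No step beyond the scatter is expected in this assay, in either direction. The estimated step, no change at the digits printed from compound 2 to compound 4 (within the scatter), stays within the scatter. For compound 4 the expected value is 32000 nM, with an estimated range of 14000 nM to 64000 nM.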

Compound 4, half-maximal cytotoxic concentration: 32000 nM
Beside the measured number, compound 4's estimate shows no gap at the digits printed, within the range that was stated.
By their numbers in this assay, from the lowest: compounds 1, 2, 3 and 4 (each within the scatter of the next).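

In this assay, going by these compounds alone, amino in place of hydrogen on a saturated chain carbon bound to an aromatic carbon and a carbonyl carbon brings no change at the digits printed from compound 2 to compound 4 (within the scatter) and gives the first comparison at a single place. This position therefore takes the amino group with no readable shift in this read-out. Nothing available explains this result.

On these data alone, whether a hydroxyl group, a carboxylic acid or a longer chain on this saturated chain carbon would read differently stays open.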